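From 4-bromophenyl to 2-fluorophenyl: an expected step

This account rests on a few compounds, and the source may have more. Where it says the series, first, only, none or still open, it means among the compounds named here.

Compound 1 `O=Cc1ccc(-c2cn3ccnc3c(-c3ccc4ncn(C5CCCCC5)c4c3)n2)cc1` gives 92.6% in a functional assay on HCT-116 cells (Homo sapiens) for inhibition, read by sulforhodamine B assay, with a stated time of 48 h, tested at 10 uM; on this read-out higher numbers stand for more inhibition at the one concentration tested (going by the name of the read-out) and lower numbers for less inhibition.
Compound 2 `Clc1ccc(-c2cn3ccnc3c(-c3ccc4ncn(C5CCCCC5)c4c3)n2)cc1` gives 7.34%.
Compound 3 `Brc1ccc(-c2cn3ccnc3c(-c3ccc4ncn(C5CCCCC5)c4c3)n2)cc1` gives 31.2%.

Compound 3 stands second highest of the three, with compound 2 nearest, a step of a number 23.9 percentage points higher from compound 2 to compound 3 (beyond the scatter), and compound 1 furthest, a step of a number 61.4 percentage points lower from compound 1 to compound 3 (beyond the scatter). Compound 4 `Fc1ccccc1-c1cn2ccnc2c(-c2ccc3ncn(C4CCCCC4)c3c2)n1` differs from compound 3 in one place: 2-fluorophenyl in place of 4-bromophenyl on an aromatic carbon. For the measured compounds named here, no measured step covers this exact change; the nearest guide is a number 23.9 percentage points higher from compound 2 to compound 3 (beyond the scatter), a modest move between two halogen-bearing phenyls, and both halogen compounds sit far below compound 1. A further halogen-bearing phenyl is therefore expected to stay in the low range, with a modest step of a number 16.2 percentage points lower from compound 3 to compound 4 (beyond the scatter) expected. Compound 4 is estimated at 15%, between 0% and 45%.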

Compound 4, a percentage reported as inhibition, at one concentration (the size of the read-out at that concentration, not a potency): 25.8%
Compound 4: middle estimate off by 10.8 percentage points, on the low side, within the range that was stated.
By their numbers in this assay, from the lowest: compound 2; then compounds 4 and 3 (each within the scatter of the next); then compound 1.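

Placing 2-fluorophenyl where 4-bromophenyl stood leaves the read-out within the scatter (a number 5.4 percentage points lower from compound 3 to compound 4 (within the scatter)), so these two halogen-bearing phenyls cannot be told apart here. Against 4-chlorophenyl the same group gives a number 18.5 percentage points higher from compound 2 to compound 4 (beyond the scatter), so halogen-bearing phenyls at this position are not all alike, yet against 4-formylphenyl it gives a number 66.8 percentage points lower from compound 1 to compound 4 (beyond the scatter). No available evidence explains these differences. As far as these compounds go, what remains open is whether the high value of compound 1 belongs to the formyl group alone, or whether a carboxylic acid or an amine on that phenyl would also reach it.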